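The compounds below may be only part of what the source reports. "The series", "measured", "known", "first", "only" and "open" are said of these compounds alone.

In a functional assay on MDA-MB-231 cells (Homo sapiens) for antiproliferative activity, read by sulforhodamine B assay, with a stated time of 72 h (a higher number here means a weaker inhibitor, a lower number a stronger inhibitor), compound 1, whose structure is `COc1c(OC(C)C)cc2occ(-c3csc4ccccc34)c(=O)c2c1OC(C)C`, gives only a limit of the assay, > 10000 nM. Compound 2, with the structure `COc1c(OC(C)C)cc2occ(-c3csc4ccccc34)c(=O)c2c1O`, likewise reaches only a limit, > 10000 nM. The change between the two is hydrogen in place of isopropyl on an oxygen on an aromatic ring. The step that the two limits leave unreadable from compound 1 to compound 2 cannot be sized, since both values sit at the limit, and the limit of > 10000 nM in this assay, at which 3 of the 3 values shown sit, records that this holds for every value gathered so far. Compound 3, with the structure `COc1c(OC(C)C)cc2c(c1OC(C)C)C(=O)/C(=C/c1csc3ccccc13)O2`, is built from the same atoms as compound 1 joined differently; the difference between the two cores is not broken down here. In this assay compound 3 also gives only a limit, > 10000 nM. For the measured compounds named here, compound 4, with the structure `COc1c(OC(C)C)cc2c(c1O)C(=O)/C(=C/c1csc3ccccc13)O2`, carries the same change as the one from compound 1 to compound 2, namely (hydrogen in place of isopropyl on an oxygen on an aromatic ring), at a place described in the same words. The expected step that the limit leaves unreadable from compound 3 to compound 4 is small, because a step that the two limits leave unreadable from compound 1 to compound 2 shows no readable movement and because the limit of > 10000 nM in this assay, at which 3 of the 3 values shown sit, places all three values at one limit. Compound 4 is therefore estimated at 15000 nM, between 8000 nM and 40000 nM, most likely reported again as a limit.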

Compound 4, half-maximal inhibitory concentration: > 10000 nM
Compound 4: only a limit was reported; the forecaster's own chance of this, stated with the estimate: 85%; the middle value lies beyond the limit too.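

In this assay compound 3 and compound 4 both stop at a limit of the assay, so the change between them, isopropoxy to hydroxy, cannot be given a size. The compounds shown leave open whether any change to these structures would give a readable value, as the picture so far is a single limit: the limit of > 10000 nM in this assay, at which 4 of the 4 values shown sit.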